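A few compounds are considered here, and "the series" means these few. Any claim that something is new, unique, unknown or untested is made for them only; others in the source may bear on it.

Measured so far in a functional assay on NCI-H460 cells (Homo sapiens) for antiproliferative activity, read by MTT assay, with a stated time of 48 h; a higher number here means a weaker inhibitor, a lower number a stronger inhibitor:
- compound 3, `O=C(CCl)Nc1ccc(SCC(=O)Nc2ccc(Cl)cn2)cc1`: 420 nM
- compound 2, `Cc1ccnc(Cl)c1NC(=O)CSc1nnc(NC(=O)CCl)s1`: 59600 nM
- compound 1, `COc1ccccc1C(=O)Nc1nnc(SCC(=O)Nc2ccc(Br)cn2)s1`: > 80000 nM

For compound 1 the value is a limit of this assay, not a number. Among the two numbers given, compound 3 stands lowest, with compound 2 far higher and well beyond the scatter. Compound 4, `O=C(CCl)Nc1ccc(SCC(=O)Nc2ccc(Cl)cc2)cc1`, differs from compound 3 by 4-chlorophenyl in place of 5-chloropyridin-2-yl on an amide-type nitrogen. For the measured compounds named here, no measured pair shows this change on its own, so its effect cannot be read from the data. The expectation is a small step, probably within or only slightly beyond the scatter, leaning towards a weaker inhibitor. Compound 4 is therefore estimated at 700 nM, within 150 nM to 3500 nM, a step of a 1.7-fold higher number from compound 3 to compound 4 (0.22 log units; within the scatter).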

Compound 4, half-maximal inhibitory concentration: 23100 nM
Estimate against measurement, compound 4: 33-fold (1.52 log units) below; the whole stated range lies below it.
By their numbers in this assay, from the lowest: compound 3; then compound 4; then compound 2. At a limit, above all of these: compound 1.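

Exchanging 5-chloropyridin-2-yl for 4-chlorophenyl on an amide-type nitrogen gives a 55-fold higher number from compound 3 to compound 4 (1.74 log units; beyond the scatter) in this assay. For the compounds shown here, this is the first pair that differs in one place, and it shows that this position is highly sensitive: swapping the pyridine ring for a carbon-only ring is enough for a large step towards weaker inhibition. Nothing measured here explains why the step is so large.

Still open, on these data alone, is how pyridin-2-yl without the chlorine, or 5-fluoropyridin-2-yl, would compare on this nitrogen. As far as these compounds go, whether the same change gives a similar step on another core also remains unknown.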